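Methoxy on the phenyl ring of compound 2

This account rests on a few compounds, and the source may have more. Where it says the series, first, only, none or still open, it means among the compounds named here.

Compound 2 `Cc1cccc(NC(=O)CN2CCC(c3ccccc3)CC2)c1` gives 170 nM in a functional assay on HEK293 cells for agonist activity at D(4) dopamine receptor (Homo sapiens), read by FLIPR; a higher number here means that more compound is needed for the effect, a lower number that less compound is needed. Among the three measured compounds its number stands second highest: compound 3 `O=C(NCN1CCC(c2cccc[n+]2[O-])CC1)c1ccccn1` gives 3150 nM, the nearest number, and compound 1 `Cc1cccc(NC(=O)CN2CCC(c3nccs3)CC2)c1` gives 1 nM, the furthest. Among the compounds with values here, the single step measured on this part of the molecule, a 170-fold higher number from compound 1 to compound 2 (2.23 log units; beyond the scatter), exchanges the whole ring on the saturated carbon and therefore says nothing about a substituent placed on the phenyl.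

Compound 4 `COc1ccccc1C1CCN(CC(=O)Nc2cccc(C)c2)CC1` differs from compound 2 by methoxy in place of hydrogen on an aromatic carbon, which read one bond further out is phenyl to 2-methoxyphenyl. Within the data shown here, no measured pair shows what a methoxy group on this ring does, so no direction can be taken from the numbers; a change of this size, without a precedent, is expected to move the number only modestly in either direction. Compound 4 is expected to give about 100 nM in this assay, within 20 nM to 500 nM. The expected step is a 1.7-fold lower number from compound 2 to compound 4 (0.23 log units; within the scatter).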

Compound 4, half-maximal effective concentration: 420 nM
Compound 4: middle estimate off by 4.2-fold (0.62 log units), on the low side; measured number inside the range.
By their numbers in this assay, from the lowest: compound 1; then compound 2; then compound 4; then compound 3.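

Methoxy is the first substituent on this phenyl ring to be read in this assay, and placed ortho to a large group it raises the number by a modest step that lies beyond the scatter (a 2.5-fold higher number from compound 2 to compound 4 (0.39 log units; beyond the scatter)). Thus 2-methoxyphenyl shows no improvement over phenyl at this position, and it stands further from the 1,3-thiazol-2-yl of compound 1 (a 420-fold higher number from compound 1 to compound 4 (2.62 log units; beyond the scatter)), so the large gap opened by leaving that ring is not narrowed. No measurement available here accounts for the upward step.

Going by these compounds, whether a hydroxy group or a fluorine atom in the same place on the phenyl ring would move the number in the same direction remains open. Also open, on these data alone, is whether methoxy would carry a similar step on another ring.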